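Swapping a benzyl for an anisyl group on the shared core

This account rests on a few compounds, and the source may have more. Where it says the series, first, only, none or still open, it means among the compounds named here.

Compound 1 `Cc1ccccc1Nc1nc(Nc2ccc(N3CCCCC3)cn2)ncc1Cl` and compound 2 `Cc1ccc(CNc2nc(Nc3ccc(N4CCN(C)CC4)cn3)ncc2Cl)cc1` share a core and were both tested in a functional assay on Jurkat cells (Homo sapiens) for inhibition, read by CCK-8 assay, with a stated time of 48 h; a higher number here means a weaker inhibitor of growth, a lower number a stronger inhibitor of growth. For compound 1 the assay gives only a limit, > 100000 nM, and not a number. Among the compounds with values here, compound 2 gives 12700 nM, the only plain number recorded so far. The other result recorded, that of compound 1, is a limit (the limit of > 100000 nM in this assay, at which 1 of the 2 values shown sits). Compound 3 `COc1cccc(Nc2nc(Nc3ccc(N4CCN(C)CC4)cn3)ncc2Cl)c1` is not yet measured. It differs from compound 2 in one place (3-methoxyphenyl in place of 4-methylbenzyl on a nitrogen on an aromatic ring). Within the data shown here, no measured pair differs in just one place, so there is no measured step to lean on. Nothing in the present data marks this change as helpful or harmful, so a step within the usual scatter of this assay is the plainest expectation, with wide uncertainty either way. The expected step from compound 2 to compound 3 is a 1.4-fold lower number from compound 2 to compound 3 (0.15 log units; within the scatter). Compound 3 is therefore estimated at 9000 nM, within a range of 1500 nM to 60000 nM.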

Compound 3, concentration for 50% growth inhibition: 15800 nM
For compound 3 the middle estimate is 1.8-fold (0.24 log units) below the measured one, within the range that was stated.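

In this assay, within the data shown here, the only measured change in one place on the shared core gives a 1.2-fold higher number from compound 2 to compound 3 (0.09 log units; within the scatter). On this nitrogen, then, 3-methoxyphenyl and 4-methylbenzyl cannot be told apart, even though the two groups differ in how the ring is joined to the nitrogen and only 3-methoxyphenyl carries a hydrogen-bond acceptor. Nothing recorded here gives a reason for this result.

Compound 1 stands only at a limit, and steps to it cannot be read: the limit of > 100000 nM in this assay, at which 1 of the 3 values shown sits. Still open, on these data alone, is whether an amine or a carboxylic acid on the ring of this group, or a longer chain joining that ring to the nitrogen, would move the number in this assay beyond the usual scatter.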